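The compounds below may be only part of what the source reports. "The series", "measured", "known", "first", "only" and "open" are said of these compounds alone.

Across the three measured compounds, compound 1 `O=C(CCCCCCc1ccccc1)c1ncc(-c2ccc(F)cc2)o1` gives 62 nM in an assay (Rattus norvegicus) for inhibition of Fatty-acid amide hydrolase 1 (Homo sapiens) (on this read-out higher numbers stand for weaker inhibition and lower numbers for stronger inhibition), compound 2 `Cc1ccc(-c2cnc(C(=O)CCCCCCc3ccccc3)o2)nc1` gives 2.8 nM, and compound 3 `NC(=O)c1ccc(-c2cnc(C(=O)CCCCCCc3ccccc3)o2)nc1` gives 1.2 nM, the lowest number of the three. The steps of a 22-fold lower number from compound 1 to compound 2 (1.35 log units; beyond the scatter) and a 52-fold lower number from compound 1 to compound 3 (1.71 log units; beyond the scatter) show that the group on this aromatic carbon moves the number strongly, while a 2.3-fold lower number from compound 2 to compound 3 (0.37 log units; beyond the scatter) is only a modest step. Compound 4 `O=C(CCCCCCc1ccccc1)c1ncc(C(=O)N2CCOCC2)o1` carries the change ((morpholin-4-yl)carbonyl in place of 5-carbamoylpyridin-2-yl on an aromatic carbon). Among the compounds with values here, no measured step exchanges the six-membered aromatic ring for a carbonyl-linked non-aromatic ring, so the direction is uncertain; because compound 3 already sits at 1.2 nM at the favourable end of the series, a rise is expected, estimated as a 33-fold higher number from compound 3 to compound 4 (1.52 log units; beyond the scatter). Compound 4 is expected to give 40 nM, with a range from 8 nM to 250 nM.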

Compound 4, inhibition constant: 24 nM
The estimate for compound 4 lay 1.7-fold (0.22 log units) above the measured number; the measured number falls inside the stated range.
By their numbers in this assay, from the lowest: compound 3; then compound 2; then compound 4; then compound 1.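

At this aromatic carbon, next to the ring oxygen, (morpholin-4-yl)carbonyl gives up much of what the 5-carbamoylpyridin-2-yl group reaches (a 20-fold higher number from compound 3 to compound 4 (1.30 log units; beyond the scatter)) and less relative to 5-methylpyridin-2-yl (an 8.6-fold higher number from compound 2 to compound 4 (0.93 log units; beyond the scatter)). A six-membered aromatic ring is nevertheless not required for a lower number than 4-fluorophenyl gives (a 2.6-fold lower number from compound 1 to compound 4 (0.41 log units; beyond the scatter)). No data on hand bear on the reason for these steps.

Open, on these data alone, is whether piperidin-1-ylcarbonyl, with a ring carbon in place of the morpholine oxygen, would shift the number. Also open, as far as these compounds go, is whether a simple dimethylamide would do the same.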